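This account rests on a few compounds, and the source may have more. Where it says the series, first, only, none or still open, it means among the compounds named here.

Compound 1, with the structure `COc1ccc(-c2cc(=O)c3c(OC)cc(OC)cc3n2C)cc1`, is the starting point of this step, yet its own standing on the numbers is blank: in a functional assay on HepG2 cells (Homo sapiens) for antiproliferative activity, with a stated time of 72 h (on this read-out lower numbers stand for an effect already at smaller amounts and higher numbers for an effect only at larger amounts of compound), compound 1 gives "not determined" (no result reported), so no number places it on this read-out. The second measured compound, compound 2 with the structure `COC(=O)c1cc(=O)c2c(OC)cc(OC)cc2n1C`, carries a methyl ester on the shared core. In this assay compound 2 gives > 19000 nM, which is a limit of the assay and not a number. The only firm point in the whole set is therefore (the limit of > 19000 nM in this assay, at which 1 of the 2 values shown sits), and it belongs to compound 2.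

The unmeasured compound 3 has the structure `COc1ccc(-c2cc(=O)c3c(OC)cc(OC)cc3n2S(=O)(=O)c2ccc(C=O)cc2)cc1`. Compared with compound 1 the change is (4-formylphenyl)sulfonyl in place of methyl on an aromatic nitrogen. Because compound 1 has no result and no step between measured compounds is available, the size and direction of this change in this assay cannot be read from any pair; the one result shown is a limit that tells only that compound 2 is weak. Compound 3 is expected to give about 8000 nM in this assay, with a range from 1500 nM to 40000 nM.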

Compound 3, half-maximal effective concentration: > 34400 nM
Compound 3: only a limit was reported (the forecaster's own chance of this, stated with the estimate: 40%); middle value at least 4.3-fold (0.63 log units) away from the limit.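

In this assay compound 3 gives > 34400 nM, which is a limit of the assay and not a number. For the compounds shown here, compound 1 has no number to set against it, and no step between compound 1 and compound 3 can be read. The compounds shown leave open how strongly a change of the group on the aromatic nitrogen moves this read-out, and in which direction.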